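Swapping the benzamide aryl group on a thiazole acid scaffold

The compounds below may be only part of what the source reports. "The series", "measured", "known", "first", "only" and "open" are said of these compounds alone.

Compounds measured so far:
Compound 1, `CCOC(=O)c1sc(-c2cccc(NC(=O)c3ccc(Cl)cc3)c2)nc1Nc1ccc(N2CCN(C)CC2)cc1`: "not determined" (no result reported) in a functional assay on Raji cells (Homo sapiens) for antiproliferative activity, read by CCK-8 assay, with a stated time of 72 h; a higher number here means a weaker inhibitor, a lower number a stronger inhibitor
Compound 2, `CN1CCN(c2ccc(Nc3nc(-c4cccc(NC(=O)c5ccccc5F)c4)sc3C(=O)O)cc2)CC1`: 13900 nM

Among the measured compounds shown here, compound 2 carries the only number, so it stands alone; compound 1, its ethyl ester relative, was run in this assay but no value came back. Compound 3, `CN1CCN(c2ccc(Nc3nc(-c4cccc(NC(=O)c5ccc(Cl)cc5)c4)sc3C(=O)O)cc2)CC1`, is the next entry to be tested. It differs from compound 2 in one place: 4-chlorophenyl in place of 2-fluorophenyl on a carbonyl carbon. For the measured compounds named here, no step between two measured compounds is available to show how this kind of exchange plays out here, so the prediction rests on compound 2 alone. Going by the values given here, with one anchor and no comparable pair, the step is expected to be a 1.2-fold lower number from compound 2 to compound 3 (0.06 log units; within the scatter), nothing beyond the usual scatter. Compound 3 is therefore expected to give about 12000 nM in this assay, within a range of 4000 nM to 40000 nM.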

Compound 3, half-maximal inhibitory concentration: 7020 nM
For compound 3 the middle estimate is 1.7-fold (0.23 log units) above the measured one, within the range that was stated.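

Among the compounds shown here, this is the first step that can be read at this place: with 4-chlorophenyl in place of 2-fluorophenyl on a carbonyl carbon, this assay gives a 2.0-fold lower number from compound 2 to compound 3 (0.30 log units; within the scatter). The halogen and its place on the phenyl ring can therefore both change at once without a shift beyond the usual scatter, though this single pair cannot separate the two changes. No measurement here offers an explanation for the result.

As far as these compounds go, whether a different group on this carbonyl carbon, such as a pyridine ring, a cyclohexyl ring or a phenyl ring bearing a dimethylamino group, would move the number further remains open. The step between the carboxylic acid of compound 3 and the ethyl ester of compound 1 cannot be read, since compound 1 gives "not determined" (no result reported).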